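Moving a fluorine around the ring in a lipophilicity series

A few compounds are considered here, and "the series" means these few. Any claim that something is new, unique, unknown or untested is made for them only; others in the source may bear on it.

Of the compounds shown here, three sharing one core have been measured in a physicochemical assay for lipophilicity, using the shake flask method, in phosphate buffer, measured as octanol-water partition, with a stated time of 85 min, at pH 7.4; on this read-out lower numbers stand for lower lipophilicity and higher numbers for higher lipophilicity. Compound 1, `Fc1ccc(-c2cn3ccnc3c(-c3ccc4ncn(C5CCCCC5)c4c3)n2)cc1`, gives 2.01 and stands highest of the three numbers. Compound 2, `c1cn2cc(-c3ccsc3)nc(-c3ccc4ncn(C5CCCCC5)c4c3)c2n1`, gives 1.81, and the step of a number 0.20 log units lower from compound 1 to compound 2 (within the scatter) lies within the scatter, so the two cannot be ordered. Compound 3, `CCc1ccc(-c2cn3ccnc3c(-c3ccc4ncn(C5CCCCC5)c4c3)n2)cc1`, gives 1.66, and the step of a number 0.35 log units lower from compound 1 to compound 3 (beyond the scatter) is modest but real. The remaining step, a number 0.15 log units lower from compound 2 to compound 3 (within the scatter), is again within the scatter.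

Compound 4, `Fc1ccccc1-c1cn2ccnc2c(-c2ccc3ncn(C4CCCCC4)c3c2)n1`, has not yet been measured. It differs from compound 1 only in how the same atoms are joined: 2-fluorophenyl in place of 4-fluorophenyl on an aromatic carbon. Among the measured compounds shown here, none of the measured steps bears directly on this change. The steps from compound 1 swap the whole aryl group or replace the fluoro with ethyl; none keeps the fluorophenyl and shifts only where the fluorine sits. The two measured changes to this part of the molecule gave one step within the scatter and one modest step, and both lowered the number.

With nothing pointing in either direction, compound 4 is expected to give 1.95, with a range from 1.55 to 2.35, meaning an expected step of a number 0.06 log units lower from compound 1 to compound 4 (within the scatter).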

Compound 4, partition coefficient: 1.95
For compound 4 middle estimate and measured number coincide at the digits printed, within the range that was stated.
By their numbers in this assay, from the lowest: compounds 3, 2, 4 and 1 (each within the scatter of the next, the first and the last beyond it).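

Keeping the fluorophenyl group and changing only where the fluorine sits gives a number 0.06 log units lower from compound 1 to compound 4 (within the scatter) in this assay, so at this position on the shared core the 2-fluorophenyl and 4-fluorophenyl groups cannot be told apart on this read-out. Compound 4 also cannot be ordered against the other two aryl groups, with a number 0.14 log units higher from compound 2 to compound 4 (within the scatter) for the swap from thiophen-3-yl and a number 0.29 log units higher from compound 3 to compound 4 (within the scatter) for the swap from 4-ethylphenyl. Compound 1 and compound 3 remain the only pair separated beyond the scatter, and compound 4 sits within the scatter of both, but no measurement shown explains why any of these aryl groups gives the number it does.

On these data alone, every group tested at this position is a single aromatic ring, so it remains open whether a different kind of group, such as an amine or a carboxylic acid on that ring, would shift the number beyond the scatter. These four compounds also leave open whether the fluorine's place would matter as little on a different core or in a different kind of assay.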